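A few compounds are considered here, and "the series" means these few. Any claim that something is new, unique, unknown or untested is made for them only; others in the source may bear on it.

Going by the values given here, in a functional assay on COLO 205 cells (Homo sapiens) for inhibition, read by sulforhodamine B assay (on this read-out lower numbers stand for stronger inhibition of growth and higher numbers for weaker inhibition of growth), compound 1 `Cc1ccc2[nH]c(-c3ccc(-c4ccc(-c5ccc(N(C)C)cc5)cc4)cc3)nc2c1` gives 9210 nM, the lower of the two numbers so far, and compound 2 `CN(C)c1ccc(-c2ccc(-c3ccc(-c4nc5ccccc5[nH]4)cc3)cc2)cc1` gives 100000 nM. Compound 3 `Cc1ccc2[nH]c(-c3ccc(-c4ccc(-c5ccc(C(F)(F)F)cc5)cc4)cc3)nc2c1` has trifluoromethyl in place of dimethylamino on an aromatic carbon of compound 1: trifluoromethyl in place of dimethylamino on an aromatic carbon. Among the compounds with values here, the only measured step, an 11-fold higher number from compound 1 to compound 2 (1.04 log units; beyond the scatter), is a different change, so it shows that one change can move the number widely but gives no direction for this one. With no clear direction to go on, the expected change is a 1.3-fold higher number from compound 1 to compound 3 (0.11 log units; within the scatter), within a wide margin of doubt. For compound 3 the estimated value is 12000 nM, with an expected range of 3000 nM to 50000 nM.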

Compound 3, concentration for 50% growth inhibition: 30600 nM
Estimate against measurement, compound 3: 2.6-fold (0.41 log units) below, within the range that was stated.
By their numbers in this assay, from the lowest: compound 1; then compound 3; then compound 2.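

Trifluoromethyl in place of dimethylamino gives a 3.3-fold higher number from compound 1 to compound 3 (0.52 log units; beyond the scatter) in this assay. Going by these compounds alone, this is the first measured change on this aromatic carbon, para to a large group, and it shows that growth inhibition here depends on the group at this position, with dimethylamino the better of the two. Nothing available explains this step. On these data alone, what a methoxy group, a primary amine or a carboxylic acid would give at this position stays open. So does whether losing the methyl from the core would matter as much with trifluoromethyl in place.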